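The compounds below may be only part of what the source reports. "The series", "measured", "known", "first", "only" and "open" are said of these compounds alone.

Compound 3 `O=C(Nc1cccc(Cl)c1)c1cccc(Br)c1O` is the point of departure. In an assay for inhibition of HSP60/HSP10 (Homo sapiens), with a stated time of 60 min (a lower number here means a stronger inhibitor, a higher number a weaker inhibitor), compound 3 gives > 100000 nM, which is a limit of the assay rather than a number. Compound 1 `O=C(Nc1cccc(Cl)c1)c1cccc(Br)c1` also reaches only the limit > 100000 nM in this assay. Compound 2 `COc1c(Br)cc(Br)cc1C(=O)Nc1cccc(Cl)c1` likewise sits at the limit > 100000 nM in this assay. The step that the two limits leave unreadable from compound 1 to compound 3 therefore has no readable size, because the limit of > 100000 nM in this assay, at which 3 of the 3 values shown sit, holds all three values. Compound 4 `COc1c(Br)cccc1C(=O)Nc1cccc(Cl)c1` differs from compound 3 by methyl in place of hydrogen on an oxygen on an aromatic ring. Within the data shown here, compound 2 already carries a methoxy group together with a second bromine and stays at its limit, so the one step that bears on this change gives no size at all. The step that the limit leaves unreadable from compound 3 to compound 4 is thus expected to be none beyond the scatter. Compound 4 is estimated at 150000 nM, between 30000 nM and 1000000 nM, most likely again a limit.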

Compound 4, half-maximal inhibitory concentration: > 100000 nM
Compound 4: a limit, no number (the forecaster's own chance of this, stated with the estimate: 85%); the middle value does not contradict the limit.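

Compound 1, compound 2, compound 3 and compound 4 all give only a limit in this assay, so no step among them can be read: the limit of > 100000 nM in this assay, at which 4 of the 4 values shown sit.

The compounds shown leave open which change to the shared core, if any, would give a readable number in this assay.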